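Chain variants on the shared core

The source may hold more compounds than are shown below. What is called first, only, known or untested is meant among the compounds shown, and "the series" means these compounds.

Measured so far:
Compound 1 `CCCCCOc1ccc(C(CC(=O)O)c2ccccc2)cc1` — 2.97 uM
Compound 2 `C/C=C/COc1ccc(C(CC(=O)O)c2ccccc2)cc1` — 2.71 uM

In a functional assay on HEK293 cells for agonist activity at Free fatty acid receptor 1 (Homo sapiens), read by calcium flux (a higher number here means that more compound is needed for the effect, a lower number that less compound is needed), compound 1 gives 2.97 uM, the highest of the two numbers shown, and compound 2 gives 2.71 uM; the step of a 1.1-fold lower number from compound 1 to compound 2 (0.04 log units; within the scatter) lies within the scatter. Compound 3 `C=C(C)CCOc1ccc(C(CC(=O)O)c2ccccc2)cc1` differs from compound 1 by 1-methylethenyl in place of propyl on a saturated chain carbon, two bonds along the chain from an oxygen on an aromatic ring. Going by the values given here, the one step bearing on this, a 1.1-fold lower number from compound 1 to compound 2 (0.04 log units; within the scatter), also places a double bond in the chain on the oxygen and changed nothing beyond the scatter, so for compound 3 a step of a 1.1-fold lower number from compound 1 to compound 3 (0.03 log units; within the scatter) is expected. Compound 3 is therefore estimated at 2.8 uM, with a range from 1.4 uM to 5.6 uM.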

Compound 3, concentration for half-maximal effect: 2.71 uM
Compound 3: middle estimate off by 1.0-fold (0.01 log units), on the high side, within the range that was stated.
By their numbers in this assay, from the lowest: compounds 2, 3 and 1 (each within the scatter of the next).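

In this assay, 1-methylethenyl in place of propyl gives a 1.1-fold lower number from compound 1 to compound 3 (0.04 log units; within the scatter), and 2-methylprop-2-en-1-yl in place of prop-1-en-1-yl gives no change at the digits printed from compound 2 to compound 3 (within the scatter). A branched chain with its double bond at another place on the chain thus stays within the scatter of both the pentyl chain and the chain of compound 2. No evidence at hand explains this flat result. Still open, from the compounds shown here alone, is whether a longer chain, a terminal phenyl or an amine on this chain would move the number beyond the scatter.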